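Cytotoxicity notes: the step from compound 3 to compound 4

The compounds below may be only part of what the source reports. "The series", "measured", "known", "first", "only" and "open" are said of these compounds alone.

In a functional assay on cells (Homo sapiens) for cytotoxicity, read by MTT assay, with a stated time of 24 h (on this read-out lower numbers stand for stronger inhibition and higher numbers for weaker inhibition), compound 1 (`CCCCCCCCCCCCCCNC(=O)[C@H](CO)/N=C/c1cccc(OC)c1`) gives 31300 nM and compound 2 (`CCCCCCCCCCCCCCNC(=O)[C@H](CO)/N=C/c1ccccc1[N+](=O)[O-]`) gives 21700 nM on the same read-out. Compound 3 (`CCCCCCCCCCCCCCNC(=O)[C@H](CO)NCc1ccccc1O`) gives 75300 nM as the highest of the three numbers. Compound 4 (`CCCCCCCCCCCCCCNC(=O)[C@H](CO)/N=C/c1ccc(Cl)cc1`) differs from compound 3 by a group of 9 heavy atoms (7 carbon, 1 nitrogen, 1 chlorine; one six-membered aromatic ring of carbon only) in place of a group of 9 heavy atoms (7 carbon, 1 nitrogen, 1 oxygen; one six-membered aromatic ring of carbon only), on a saturated chain carbon bound to a carbonyl carbon and a saturated chain carbon and is not yet measured. The step of a 1.4-fold lower number from compound 1 to compound 2 (0.16 log units; within the scatter) lies within the scatter, so the ring substituent offers little guidance. Compound 4 shares with compound 1 the carbon with a double bond to nitrogen, so a 2.4-fold higher number from compound 1 to compound 3 (0.38 log units; beyond the scatter) is the closest guide, read in reverse. A modest drop is expected in this assay as a 3.0-fold lower number from compound 3 to compound 4 (0.48 log units; beyond the scatter) on this reading. Compound 4 is estimated at 25000 nM (range 12000 nM to 50000 nM).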

Compound 4, half-maximal inhibitory concentration: 27500 nM
Beside the measured number, compound 4's estimate is 1.1-fold (0.04 log units) below it, and the stated range covers the measured number.
By their numbers in this assay, from the lowest: compounds 2, 4 and 1 (each within the scatter of the next); then compound 3.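

In this assay, 4-chlorophenyl on a carbon with a double bond to nitrogen is not told apart from the other two ring groups: a 1.3-fold higher number from compound 2 to compound 4 (0.10 log units; within the scatter) and a 1.1-fold lower number from compound 1 to compound 4 (0.06 log units; within the scatter) both lie within the scatter. Replacing (2-hydroxybenzyl)amino gives a 2.7-fold lower number from compound 3 to compound 4 (0.44 log units; beyond the scatter) as a modest step, but the ring group and the link to it change together. No supporting evidence bears on the cause of this step. As far as these compounds go, the separate contributions of the link and the ring group remain open, as does the effect of a carboxylic acid on the ring or a shorter chain.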